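Solubility estimate for a tetrahydroisoquinoline analogue

The compounds below may be only part of what the source reports. "The series", "measured", "known", "first", "only" and "open" are said of these compounds alone.

Measured compounds:
- compound 1, `COc1ccc2[nH]c(C(=O)N3CC(=O)N(Cc4ccccc4)[C@@H](CN4CCCC4)C3)cc2c1`: > 25000 nM
- compound 2, `COc1ccc2[nH]c(C(=O)N3CC(=O)N(Cc4ccccc4)[C@@H](N4CCc5ccccc54)C3)cc2c1`: 7000 nM
- compound 3, `COc1ccc2[nH]c(C(=O)N3CC(=O)N(Cc4ccccc4)[C@@H](CN4C(=O)c5ccccc5C4=O)C3)cc2c1`: > 100000 nM

In a physicochemical assay for solubility, read by spectrophotometry, in phosphate buffer, with a stated time of 2 h, at pH 7.4 (on this read-out higher numbers stand for higher solubility and lower numbers for lower solubility), the three measured compounds share one core and differ in a single group on the saturated ring. Compound 3 gives > 100000 nM, which is a limit of this assay rather than a number. Compound 1 gives > 25000 nM, also a limit. Compound 2 gives 7000 nM.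

The unmeasured compound 4, `COc1ccc2[nH]c(C(=O)N3CC(=O)N(Cc4ccccc4)[C@@H](CN4CCc5ccccc5C4)C3)cc2c1`, differs from compound 3 in this way: a group of 10 heavy atoms (9 carbon, 1 nitrogen; one six-membered non-aromatic ring with 1 hetero atom, one six-membered aromatic ring of carbon only) in place of a group of 11 heavy atoms (8 carbon, 1 nitrogen, 2 oxygen; one five-membered non-aromatic ring with 1 hetero atom, one six-membered aromatic ring of carbon only), on a saturated chain carbon bound to a saturated ring carbon. Among the measured compounds shown here, two measured steps bear on it. The step of an at least 14-fold higher number from compound 2 to compound 3 (1.15 log units; beyond the scatter) shows that the group present in compound 3 goes with the highest reading in the set. The step that the two limits leave unreadable from compound 1 to compound 3 cannot be read, since both ends sit at limits, the limit of > 100000 nM in this assay, at which 1 of the 3 values shown sits, and (the limit of > 25000 nM in this assay, at which 1 of the 3 values shown sits). Compound 4 carries a group on the same chain carbon as compound 1 does, so its reading is expected to fall between those of compound 1 and compound 3, meaning an expected step of an at least 3.3-fold lower number from compound 3 to compound 4 (0.52 log units; beyond the scatter) downward. Compound 4 is therefore estimated at 30000 nM, with a range from 8000 nM to 100000 nM.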

Compound 4, solubility: 9000 nM
The estimate for compound 4 lay 3.3-fold (0.52 log units) above the measured number; the range from low to high includes it.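

On the saturated chain carbon bound to a saturated ring carbon, a six-membered aromatic ring in the group does not settle the reading in this assay, since the group of compound 3 carries one too and yet 1,2,3,4-tetrahydroisoquinolin-2-yl gives an at least 11-fold lower number from compound 3 to compound 4 (1.04 log units; beyond the scatter) and this step starts from a limit, not a number: the limit of > 100000 nM in this assay, at which 1 of the 4 values shown sits.
Replacing pyrrolidin-1-yl with 1,2,3,4-tetrahydroisoquinolin-2-yl at that same place gives an at least 2.7-fold lower number from compound 1 to compound 4 (0.44 log units; beyond the scatter) and this step also starts from a limit: the limit of > 25000 nM in this assay, at which 1 of the 4 values shown sits.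
The new group on its chain carbon also brings the reading level with the 2,3-dihydro-1H-indol-1-yl group of compound 2, as a 1.3-fold higher number from compound 2 to compound 4 (0.11 log units; within the scatter) leaves the two readings indistinguishable.

As far as these compounds go, the true sizes of the steps from compound 1 and compound 3 stay unknown, and nothing here separates the part played by the two carbonyl groups of compound 3 from that of its five-membered ring. A morpholine on the same chain carbon, or a carboxylic acid on the aromatic ring of the 1,2,3,4-tetrahydroisoquinolin-2-yl group, lies outside the compounds shown, so how such groups would read remains open.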